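Dropping the Methoxy Group of Compound 1

The compounds below may be only part of what the source reports. "The series", "measured", "known", "first", "only" and "open" are said of these compounds alone.

Measured compounds:
compound 1 `COc1ccc(C(=O)Nc2cc3ccc(OC4CCN(C)CC4)c(C)c3oc2=O)cc1CC=C(C)C`: 1410 nM
compound 2 `C=CCc1cc(C(=O)Nc2cc3ccc(OC4CCN(C)CC4)c(C)c3oc2=O)ccc1OC(C)=O`: 2260 nM

Both compounds were tested in a functional assay on SK-BR-3 cells (Homo sapiens) for antiproliferative activity; on this read-out lower numbers stand for stronger inhibition and higher numbers for weaker inhibition. Going by the values given here, compound 1 carries the lower of the two numbers, with compound 2 as its only neighbour, but the gap between them lies within the usual scatter of repeated measurements, so neither compound can be called the stronger inhibitor on this read-out.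

The next compound, compound 3 `CC(C)=CCc1cccc(C(=O)Nc2cc3ccc(OC4CCN(C)CC4)c(C)c3oc2=O)c1`, has not yet been measured in this assay. It differs from compound 1 in a single place: hydrogen in place of methoxy on an aromatic carbon. Among the compounds with values here, no pair of measured compounds shares this change, so there is no direct guide for the size of the step, and the two measured values themselves offer only a sense of how close compounds of this kind tend to sit.

The step of a 1.3-fold higher number from compound 1 to compound 3 (0.13 log units; within the scatter) is expected to be small, probably a slightly higher number, and not beyond the scatter. Compound 3 is therefore expected to give about 1900 nM, with a likely range from 800 nM to 4500 nM.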

Compound 3, half-maximal inhibitory concentration: 1680 nM
For compound 3 the middle estimate is 1.1-fold (0.05 log units) above the measured one; low and high end bracket the measured number.
By their numbers in this assay, from the lowest: compounds 1, 3 and 2 (each within the scatter of the next).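

Exchanging the methoxy group for hydrogen on the aromatic carbon ortho to the 3-methylbut-2-en-1-yl group gives, in this assay, a 1.2-fold higher number from compound 1 to compound 3 (0.08 log units; within the scatter). Going by these compounds alone, this pair is the first direct reading at this position, and it shows that the two compounds cannot be told apart on this read-out: with the hydrogen in place, compound 3 keeps a number of the same size as compound 1, so the methoxy group, with its one hydrogen-bond acceptor, is not required to reach that level in this pair. Nothing available explains this result, and the reason for it stays unknown.

Only methoxy and hydrogen are shown on this carbon, so it remains open whether a hydroxyl group, an amine, a carboxylic acid or a longer chain such as butoxy would also leave the number within the scatter of compound 1 or move it clearly. As far as these compounds go, it is also open whether the same exchange would give so small a step in a compound with a different group at the ortho carbon, such as a plain propyl chain.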